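Removing a Methyl Group From a Weakly Cytotoxic Imide

A few compounds are considered here, and "the series" means these few. Any claim that something is new, unique, unknown or untested is made for them only; others in the source may bear on it.

Compound 1 `Cc1ccc(N2C(=O)C/C(=C\c3cccc(C(=O)Nc4cccc(F)c4)c3)C2=O)cc1` carries a methyl group on the ring attached to the imide nitrogen. In an ADME assay on HCT-116 cells (Homo sapiens) for cytotoxicity, read by MTT assay, with a stated time of 72 h (a higher number here means a weaker inhibitor, a lower number a stronger inhibitor), compound 1 gives > 100000 nM, which is a limit of the assay rather than a number. Two related compounds have also been measured, compound 2 `CCOc1ccc(NC(=O)c2cccc(/C=C3\CC(=O)N(c4ccccc4)C3=O)c2)cc1` and compound 3 `CCc1cccc(NC(=O)c2cccc(/C=C3\CC(=O)N(Cc4ccccc4)C3=O)c2)c1`. In this assay compound 2 gives 84800 nM. In this assay compound 3 gives 80600 nM. All three sit at the weak end of what this assay can report, and the limit of > 100000 nM in this assay, at which 1 of the 3 values shown sits, marks where compound 1 stands.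

Compound 4 `O=C(Nc1cccc(F)c1)c1cccc(/C=C2\CC(=O)N(c3ccccc3)C2=O)c1` is the next compound. It differs from compound 1 in one place: hydrogen in place of methyl on an aromatic carbon. The shared core and the fluorophenyl amide are unchanged.

Within the data shown here, no step between measured compounds has been determined, so the size of this step can only be expected. Compound 2, which has a bare phenyl on the imide nitrogen, gives 84800 nM. On that basis the step is expected to be none beyond the scatter: a number no higher from compound 1 to compound 4 (the limit leaves the size open). Compound 4 is expected to give about 100000 nM in this assay, within a range from 50000 nM to 300000 nM, and a limit rather than a number is a real possibility.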

Compound 4, half-maximal inhibitory concentration: > 100000 nM
Compound 4 gave a limit, no number; the forecaster's own chance of this, stated with the estimate: 55%; the middle value lies on the limit itself.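

Taking away the methyl group leaves compound 4 where compound 1 stands in this assay, at a limit of the assay and not at a number: the limit of > 100000 nM in this assay, at which 2 of the 4 values shown sit. With both compounds at that limit, the step from 4-methylphenyl to phenyl cannot be read, so the result neither shows that the methyl group matters nor shows that it does not. On the amide side, 3-fluorophenyl in place of 4-ethoxyphenyl on an amide-type nitrogen gives an at least 1.1-fold higher number from compound 2 to compound 4 (0.07 log units; that floor lies within the scatter), so this floor alone does not separate the two compounds.

The compounds shown leave open whether any other group at this place on the ring, such as an amine or a carboxylic acid, would bring the value inside the range the assay can report. They also leave open how the change from 4-methylphenyl to phenyl reads on a compound that gives a number, as compound 2 does, since a 4-methylphenyl partner of compound 2 would turn this same change into a step of readable size.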